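The source may report more compounds than this note shows. Statements on the series, on what has been measured and on what is new or still open speak of the compounds shown alone.

Of the compounds shown here, three sharing one core have been tested in a functional assay on the whole organism (strain Sprague-Dawley) for inhibition, with Rattus norvegicus as the target; a higher number here means that more compound is needed for the effect, a lower number that less compound is needed. Compound 1 `O=c1c(-c2nn[nH]n2)c[nH]c2c(F)ccc(F)c12` gives 10 mg/kg. Compound 2 `CCc1cccc2c(=O)c(-c3nn[nH]n3)c[nH]c12` reaches only the limit of the assay, > 25 mg/kg, not a number. Compound 3 `CC(C)c1cccc2c(=O)c(-c3nn[nH]n3)c[nH]c12` gives 10 mg/kg, level with compound 1 within the scatter. For the measured compounds named here, the single measured step, an at least 2.5-fold lower number from compound 2 to compound 3 (0.39 log units; beyond the scatter), concerns a saturated chain and not fluoro. Compound 4 `O=c1c(-c2nn[nH]n2)c[nH]c2c(F)cccc12` differs from compound 3 by fluoro in place of isopropyl on an aromatic carbon. Going by the values given here, no measured step swaps isopropyl for fluoro, so the change has no direct precedent; compound 1, which carries fluoro, gives 10 mg/kg, the same as compound 3. Compound 4 is therefore expected to stay near compound 3, with a 1.2-fold higher number from compound 3 to compound 4 (0.08 log units; within the scatter) likely inside the scatter. The estimate for compound 4 is 12 mg/kg, ranging from 5 mg/kg to 30 mg/kg.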

Compound 4, minimum effective dose: 10 mg/kg
Compound 4: middle estimate off by 1.2-fold (0.08 log units), on the high side; low and high end bracket the measured number.
By their numbers in this assay, from the lowest: compounds 1, 3 and 4 (each within the scatter of the next). At a limit, above all of these: compound 2.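

Fluoro in place of isopropyl on this aromatic carbon gives no change at the digits printed from compound 3 to compound 4 (within the scatter) in this assay, and hydrogen in place of the other fluoro gives no change at the digits printed from compound 1 to compound 4 (within the scatter). Ethyl at this carbon stands apart, with an at least 2.5-fold lower number from compound 2 to compound 4 (0.39 log units; beyond the scatter), so the count of heavy atoms in the group does not put these groups in order. Compound 2 sits at a limit, not a number: the limit of > 25 mg/kg in this assay, at which 1 of the 4 values shown sits.

What stays open is why ethyl alone differs from both isopropyl and fluoro. How an amine or a longer chain on this carbon would compare is also unknown.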